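Moving the methyl on the aryl ketone of compound 3

A few compounds are considered here, and "the series" means these few. Any claim that something is new, unique, unknown or untested is made for them only; others in the source may bear on it.

For the measured compounds named here, compound 3 `COc1cc(-c2nnc(SCC(=O)c3ccc(C)cc3)n2N2C(=O)c3ccccc3C2=O)cc(OC)c1OC` is the only member of the set with a number in a functional assay on MKN-45 cells (Homo sapiens) for cytotoxicity, read by MTT assay, with a stated time of 48 h (a lower number here means a stronger inhibitor, a higher number a weaker inhibitor), where compound 3 gives 9620 nM. Compound 1 `CCCc1nnc(SCC(=O)c2ccc(C)cc2)n1N1C(=O)c2ccccc2C1=O` reaches only the limit of this assay, > 200000 nM. Compound 2 `C=CCSc1nnc(-c2cc(OC)c(OC)c(OC)c2)n1N1C(=O)c2ccccc2C1=O` likewise stops at the limit, > 200000 nM. Both steps toward compound 3 start from that limit of > 200000 nM in this assay, at which 2 of the 3 values shown sit: an at least 20-fold lower number from compound 1 to compound 3 (1.31 log units; beyond the scatter) and an at least 20-fold lower number from compound 2 to compound 3 (1.31 log units; beyond the scatter), each large. Compound 4 `COc1cc(-c2nnc(SCC(=O)c3ccccc3C)n2N2C(=O)c3ccccc3C2=O)cc(OC)c1OC` differs from compound 3 only in the aryl ketone: 2-methylphenyl in place of 4-methylphenyl on a carbonyl carbon. Neither measured step touches this part of the molecule; one exchanges the group on the aromatic carbon, the other the group on the chain carbon bound to sulfur, so neither gives a direct reading on moving the methyl within that ring. The expectation is therefore a step within the scatter, a 1.2-fold higher number from compound 3 to compound 4 (0.10 log units; within the scatter), with a wide range reflecting the absence of any measured precedent. For compound 4 the estimate in this assay is 12000 nM, expected between 4000 nM and 40000 nM.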

Compound 4, half-maximal inhibitory concentration: > 200000 nM
Compound 4 ended at the assay's limit (the forecaster's own chance of this, stated with the estimate: 10%); at least 16-fold (1.22 log units) between middle value and limit.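

In this assay, for the compounds shown here, the aryl ketone ring proves to be a sensitive place, a part of the molecule that the earlier steps left untouched: an at least 20-fold higher number from compound 3 to compound 4 (1.31 log units; beyond the scatter). This step exchanges no atoms, so 4-methylphenyl on the carbonyl carbon cannot be treated as interchangeable with 2-methylphenyl, even with the rest of compound 3 kept intact. Among the compounds shown, the number in compound 3 therefore depends on the place of the methyl as well as on the two groups exchanged earlier, while the step from compound 2 to compound 4 joins two limits and cannot be read.

As far as these compounds go, whether the methyl is needed at all remains open, as does the outcome of phenyl without it or of an amine or carboxylic acid in its place. Only compound 3 offers a number to build on: the limit of > 200000 nM in this assay, at which 3 of the 4 values shown sit.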